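Swapping methyl for fluoro in a cytotoxicity test

This account rests on a few compounds, and the source may have more. Where it says the series, first, only, none or still open, it means among the compounds named here.

In an ADME assay on BJ cells (Homo sapiens) for cytotoxicity, with a stated time of 72 h (a lower number here means that less compound is needed, a higher number that more compound is needed for the effect), compound 1 (`COc1ccc(-c2nc3ccccc3o2)cc1NC(=O)c1cc([N+](=O)[O-])ccc1Cl`) gives only a limit (> 25000 nM) and no exact number. Compound 2 (`O=C(Nc1cccc(-c2nc3ccccc3o2)c1)c1cc([N+](=O)[O-])ccc1Cl`) also gives only a limit (> 25000 nM) here. Compound 3 (`Cc1ccc(-c2nc3ccccc3o2)cc1NC(=O)c1cc([N+](=O)[O-])ccc1Cl`) likewise stands at a limit (> 14000 nM) and so has no exact number either. Compound 4 (`O=C(Nc1cc(-c2nc3ccccc3o2)ccc1F)c1cc([N+](=O)[O-])ccc1Cl`) differs from compound 3 by one swap (fluoro in place of methyl on an aromatic carbon), fluoro in place of methyl on an aromatic carbon. The three measured swaps at that carbon give no usable size (a step that the two limits leave unreadable from compound 1 to compound 2; a step that the two limits leave unreadable from compound 1 to compound 3; a step that the two limits leave unreadable from compound 2 to compound 3), so no step beyond the scatter is expected. The estimated step is small (a step that the limit leaves unreadable from compound 3 to compound 4) in either direction. Compound 4 is expected near 22000 nM with an estimated range from 10000 nM to 40000 nM for its value.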

Compound 4, half-maximal effective concentration: > 25000 nM
Compound 4 gave a limit, no number; the forecaster's own chance of this, stated with the estimate: 85%; at least 1.1-fold (0.05 log units) between middle value and limit.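

Among the compounds shown here, compound 4 stands only at a limit, as do compound 1, compound 2 and compound 3, so no step among them can be read. Going by these compounds, whether fluoro, methyl, methoxy or hydrogen on that carbon changes the result in this assay stays open.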